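The source may hold more compounds than are shown below. What is called first, only, known or untested is meant among the compounds shown, and "the series" means these compounds.

Four compounds are compared in a functional assay on HL-60 cells (Homo sapiens) for antiproliferative activity, with a stated time of 72 h; a higher number here means a weaker inhibitor of growth, a lower number a stronger inhibitor of growth. In this assay compound 1 `C=C(CCCC)C(=O)c1ccc(OCC(=O)O)c(C)c1C` gives 14400 nM. Compound 2 `C=C(CCCC)C(=O)c1ccc(OC(C)C(=O)O)c(C)c1C` gives 12100 nM in this assay, and it is turned into compound 1 by one change: hydrogen in place of methyl on a saturated chain carbon bound to a carbonyl carbon and an oxygen on an aromatic ring. The measured size of that change is a 1.2-fold higher number from compound 2 to compound 1 (0.08 log units; within the scatter), so the two numbers cannot be told apart.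

Compound 3 `C=C(C)C(=O)c1ccc(OC(C)C(=O)O)cc1C` has another core; the difference between the core of compound 2 and the core of compound 3 is not broken down here. For compound 3 this assay reports only a limit, > 60000 nM, and not a number. That value is the limit of > 60000 nM in this assay, at which 1 of the 3 values shown sits.

Compound 4 `C=C(C)C(=O)c1ccc(OCC(=O)O)cc1C` has not yet been measured in this assay. For the measured compounds named here, it arises from compound 3 by the change (hydrogen in place of methyl on a saturated chain carbon bound to a carbonyl carbon and an oxygen on an aromatic ring), which is the same change, at the same place, as the one from compound 2 to compound 1. Since that earlier step, a 1.2-fold higher number from compound 2 to compound 1 (0.08 log units; within the scatter), sits within the scatter, the same change is expected to leave the growth inhibition of compound 3 essentially where it is. Compound 4 is therefore estimated at about 80000 nM, with a range from 30000 nM to 200000 nM. The expected step is a step that the limit leaves unreadable from compound 3 to compound 4, and it is most likely that the assay will again report only a limit. This expectation rests on compound 2 and the step of a 1.2-fold higher number from compound 2 to compound 1 (0.08 log units; within the scatter).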

Compound 4, concentration for 50% growth inhibition: > 60000 nM
Compound 4: only a limit was reported; the forecaster's own chance of this, stated with the estimate: 85%; the middle value does not contradict the limit.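

Compound 3 and compound 4 both reach only a limit in this assay, so no step can be read between them: the limit of > 60000 nM in this assay, at which 2 of the 4 values shown sit.

The compounds shown leave open whether the change from 1-carboxyethoxy to carboxymethoxy does anything at all on the core of compound 3, and how far growth inhibition on that core really lies from the values of compound 1 and compound 2.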